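Adding a second methoxy group to compound 2

The source may report more compounds than this note shows. Statements on the series, on what has been measured and on what is new or still open speak of the compounds shown alone.

In a functional assay on HeLa cells (Homo sapiens) for antiproliferative activity, with a stated time of 48 h (on this read-out higher numbers stand for weaker inhibition and lower numbers for stronger inhibition), compound 1 `C=C(Br)C(=O)Nc1ccc(C(=O)/C=C/c2ccc(OC)cc2)cc1` gives 310 nM and compound 2 `C=C(Br)C(=O)Nc1ccc(C(=O)/C=C/c2cccc(OC)c2)cc1` gives 500 nM. These two numbers lie within the usual scatter of each other, so compound 2 cannot yet be told apart from compound 1. Compound 3 `C=C(Br)C(=O)Nc1ccc(C(=O)/C=C/c2ccc(OC)c(OC)c2)cc1` is compound 2 with one further group: methoxy in place of hydrogen on an aromatic carbon, ortho to a methoxy group and para to a large group. For the measured compounds named here, only one measured step bears on this, the shift of the methoxy group on the aromatic ring, a 1.6-fold higher number from compound 1 to compound 2 (0.21 log units; within the scatter). That step is small and within the scatter. Going by the values given here, no measured compound shows what a second methoxy group does, so no step beyond the scatter is expected in this assay, and no direction can be favoured. The expected change is a 1.3-fold lower number from compound 2 to compound 3 (0.10 log units; within the scatter). For compound 3 the estimated value is 400 nM, with a likely range from 170 nM to 900 nM.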

Compound 3, half-maximal inhibitory concentration: 770 nM
Beside the measured number, compound 3's estimate is 1.9-fold (0.28 log units) below it; low and high end bracket the measured number.
By their numbers in this assay, from the lowest: compounds 1, 2 and 3 (each within the scatter of the next, the first and the last beyond it).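

In this assay, methoxy in place of hydrogen on the aromatic carbon ortho to a methoxy group and para to a large group gives a 1.5-fold higher number from compound 2 to compound 3 (0.19 log units; within the scatter), so at this position the added group cannot be told apart from hydrogen. For the compounds shown here, the same two-methoxy ring, read against the other single-methoxy ring, gives a 2.5-fold higher number from compound 1 to compound 3 (0.40 log units; beyond the scatter), a modest weakening and the first step in this set to stand clear of the scatter, so a second methoxy group brings no stronger inhibition in either comparison. Nothing available explains this result.

Going by these compounds, whether a hydroxy group, a chlorine atom or a longer ethoxy chain on this aromatic carbon would behave like methoxy stays open. So does the effect of a third methoxy group on the same ring.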